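The source may report more compounds than this note shows. Statements on the series, on what has been measured and on what is new or still open speak of the compounds shown alone.

Measured so far in an assay on isolated protein for displacement of a labelled ligand from Apoptosis regulator Bcl-2 (Homo sapiens), read by fluorescence polarization; on this read-out lower numbers stand for stronger inhibition and higher numbers for weaker inhibition:
- compound 1 `CC1(C)CCN(c2ccc(C(=O)NS(=O)(=O)c3ccc(NC(C)(C)CSc4ccccc4)c([N+](=O)[O-])c3)cc2)CC1` gives 67 nM
- compound 2 `CN(C)CC[C@H](CSc1ccccc1)Nc1ccc(S(=O)(=O)NC(=O)c2ccc(N3CCC(=Cc4ccccc4C#N)CC3)cc2)cc1[N+](=O)[O-]` gives 13 nM
- compound 3 `CN(C)CC[C@H](CSc1ccccc1)Nc1ccc(S(=O)(=O)NC(=O)c2ccc(N3CCN(Cc4ccccc4)CC3)cc2)cc1[N+](=O)[O-]` gives 39.8 nM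

Compound 3 stands second highest of the three numbers in this assay. Its gap to compound 1 is within the scatter; compound 2 sits beyond the scatter below it, being the only one of the three with a substituted pendant aromatic ring.

Compound 4 `CN(C)CC[C@H](CSc1ccccc1)Nc1ccc(S(=O)(=O)NC(=O)c2ccc(N3CCN(Cc4ccccc4C(F)(F)F)CC3)cc2)cc1[N+](=O)[O-]` differs from compound 3 by trifluoromethyl in place of hydrogen on an aromatic carbon. Among the compounds with values here, no measured pair shows that change, so the expectation rests only on the spread of the three numbers. A small step downward, or none beyond the scatter, is expected; the step from compound 3 to compound 4 is estimated as a 1.6-fold lower number from compound 3 to compound 4 (0.20 log units; within the scatter). Compound 4 is expected at 25 nM, within a range of 8 nM to 80 nM.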

Compound 4, inhibition constant: < 1 nM
Compound 4: no number, only a limit (the forecaster's own chance of this, stated with the estimate: 2%); middle value at least 25-fold (1.39 log units) away from the limit.
By their numbers in this assay, from the lowest: compound 2; then compounds 3 and 1 (each within the scatter of the next). At a limit, below all of these: compound 4.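

Changing benzyl to 2-(trifluoromethyl)benzyl gives an at least 39-fold lower number from compound 3 to compound 4 (1.59 log units; beyond the scatter), so a single substitution on an aromatic carbon, ortho to a large group, can move this series far beyond the scatter. Within the data shown here, no earlier pair isolated a change at this place, so its sensitivity could not be seen before. The value of compound 4 is a limit and not a number: the limit of < 1 nM in this assay, at which 1 of the 4 values shown sits.

On these data alone, the full size of the step therefore stays open. Also open, as far as these compounds go, is whether a methyl group, a chlorine atom or an amine at this place would act like trifluoromethyl.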